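A few compounds are considered here, and "the series" means these few. Any claim that something is new, unique, unknown or untested is made for them only; others in the source may bear on it.

Measured so far:
compound 1 `Cc1cc(Cl)cc(-c2ccnc3cc(CN4C(=O)C5C(C4=O)C5(C)C)sc23)c1C[C@@H]1CNCCO1` — 0.44 nM
compound 2 `Cc1cc(Cl)cc(-c2ccnc3cc(CN4C(=O)C5C(C4=O)C5(C)C)sc23)c1OC1CCCNC1` — 2.4 nM

In an assay on isolated protein for inhibition of ubiquitin carboxyl-terminal hydrolase 7 (Homo sapiens), read by fluorescence, with stated times of 30 min and 1 h (a higher number here means a weaker inhibitor, a lower number a stronger inhibitor), compound 2 stands highest of the two numbers shown; its only neighbour is separated from it by a 5.5-fold higher number from compound 1 to compound 2 (0.74 log units; beyond the scatter). Compound 3 `Cc1cc(Cl)cc(-c2ccnc3cc(CN4C(=O)C5C(C4=O)C5(C)C)sc23)c1NC1CCCNC1` differs from compound 2 in one place: (piperidin-3-yl)amino in place of (piperidin-3-yl)oxy on an aromatic carbon. Among the measured compounds shown here, the single measured step exchanges a different group altogether, so no measured step here tests (piperidin-3-yl)amino in place of (piperidin-3-yl)oxy. With nothing to guide a direction, the expectation for compound 3 is no step beyond the scatter, no change at the digits printed from compound 2 to compound 3 (within the scatter). Compound 3 is therefore estimated at 2.4 nM, within a range of 0.8 nM to 7 nM.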

Compound 3, half-maximal inhibitory concentration: 0.78 nM
Compound 3: middle estimate off by 3.1-fold (0.49 log units), on the high side, and the stated range ends above it.
By their numbers in this assay, from the lowest: compounds 1 and 3 (each within the scatter of the next); then compound 2.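

On the aromatic carbon carrying this side group, the atom that links the piperidine ring matters: replacing the oxygen link with an amino link gives a 3.1-fold lower number from compound 2 to compound 3 (0.49 log units; beyond the scatter) in this assay for this pair. The link change also adds a hydrogen-bond donor, but nothing shows whether that donor is responsible. Compound 3 and compound 1 cannot be separated, with a 1.8-fold higher number from compound 1 to compound 3 (0.25 log units; within the scatter) between them, even though their side groups differ in both ring and link. No measurement shown here explains these results.
Still open, going by these compounds, is how a methylene link or a methylamino link to the same piperidin-3-yl ring would compare.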